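A Shorter Ether Chain on the Amine of Compound 3

A few compounds are considered here, and "the series" means these few. Any claim that something is new, unique, unknown or untested is made for them only; others in the source may bear on it.

Of the compounds shown here, three sharing one core have been measured in an in vitro assay on 293-EBNA cells for binding affinity to corticotropin-releasing factor receptor 1 (Homo sapiens); a lower number here means a stronger inhibitor, a higher number a weaker inhibitor. Compound 1 `CCCCN(CC)c1nc(C)nc2c1nnn2-c1c(C)cc(C)cc1C` gives 27.5 nM, and compound 2 `CCCCN(CC)c1nc(C)nc2c1nnn2-c1c(C)cc(C)nc1C` gives 65 nM. Compound 3 `COCC(COC)Nc1nc(C)nc2c1nnn2-c1ccc(C(C)C)cc1Br` gives 10.3 nM, the lowest number of the three; the gap to compound 1 and the wider gap to compound 2 both lie beyond the usual scatter, so compound 3 stands as the strongest inhibitor among the measured set.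

The step to compound 4 `COCCCNc1nc(C)nc2c1nnn2-c1ccc(C(C)C)cc1Br` alters only the chain on the amine: 3-methoxypropyl in place of 2-methoxy-1-(methoxymethyl)ethyl on a nitrogen on an aromatic ring. Every other part of compound 3 is kept, including the aryl group on the shared core.

Among the compounds with values here, no measured pair in this set shows what happens when a branched ether chain on this nitrogen is replaced by a straight one, so there is no step to lean on. With one ether arm removed, a modest weakening is expected rather than an improvement, though a result within the scatter would not surprise. Compound 4 is therefore estimated at 20 nM in this assay, with a plausible range from 6 nM to 70 nM, a step of a 1.9-fold higher number from compound 3 to compound 4 (0.29 log units; within the scatter) expected on the way from the branched chain to the straight one.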

Compound 4, inhibition constant: 291 nM
Compound 4: the middle estimate sits 15-fold (1.16 log units) below what was measured; the whole stated range lies below it.
By their numbers in this assay, from the lowest: compound 3; then compound 1; then compound 2; then compound 4.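

In this assay, replacing 2-methoxy-1-(methoxymethyl)ethyl with 3-methoxypropyl on this nitrogen on an aromatic ring comes with a 28-fold higher number from compound 3 to compound 4 (1.45 log units; beyond the scatter), a large step. Within the data shown here, with the aryl group and the rest of compound 3 kept, this is the first sign in the set that the chain on this nitrogen alone can move the number by a wide margin, so the two ether chains are far from interchangeable here. The change alters branching, chain size and the count of hydrogen-bond acceptors all at once, and this single pair cannot separate them, while nothing at hand bears on what lies behind the step.

The compounds shown leave open whether the branch or the second methoxy group matters more, which a branched chain carrying a hydroxyl in place of one methoxy, or a plain 1-ethylpropyl group, could help to settle. They also leave open whether the same change on the amine would give a step of similar size with the aryl group of compound 1 on the shared core.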